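The compounds below may be only part of what the source reports. "The series", "measured", "known", "first", "only" and "open" are said of these compounds alone.

Measured compounds:
compound 1 `COC(=O)CCCNC(=O)CN1CN(c2ccccc2)C2(CCN(C(=O)c3ccc(C4CCCCC4)cc3)CC2)C1=O` with 2500 nM in an assay on HEK293 cells for displacement of a labelled ligand from NPC1-like intracellular cholesterol transporter 1 (Homo sapiens); a lower number here means a stronger inhibitor, a higher number a weaker inhibitor
compound 2 `CC(C)(C)c1ccc(C(=O)N2CCC3(CC2)C(=O)N(CC(=O)N2CCCC(O)C2)CN3c2ccccc2)cc1` with 12200 nM
compound 3 `CC(C)(C)c1ccc(C(=O)N2CCC3(CC2)C(=O)N(CC(=O)NCCCCO)CN3c2ccccc2)cc1` with 19200 nM

Compound 1 gives the lowest number of the three, and its gaps to compound 2 and to compound 3 both lie beyond the scatter. Compound 2 and compound 3 differ from each other only in the group on the amide carbonyl, and a 1.6-fold higher number from compound 2 to compound 3 (0.20 log units; within the scatter).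

Compound 4 `O=C(CN1CN(c2ccccc2)C2(CCN(C(=O)c3ccc(C4CCCCC4)cc3)CC2)C1=O)NCO` is derived from compound 1 by a single change: hydroxy in place of 2-(methoxycarbonyl)ethyl on a saturated chain carbon bound to an amide-type nitrogen. The 2-(methoxycarbonyl)ethyl chain leaves and a hydroxy group enters on the same chain carbon, so a six-atom ester tail is replaced by a single oxygen.

Going by the values given here, no measured pair shows exactly this change. Among the compounds with values here, the only step in the same region of the molecule is the one from compound 2 to compound 3, which stayed within the scatter. Compound 2 and compound 3, both carrying a hydroxy-bearing group on the amide, show higher numbers than the ester-bearing compound 1, but they also differ from it elsewhere, so no direct reading is possible. A modest weakening is therefore expected, with a 2.0-fold higher number from compound 1 to compound 4 (0.30 log units; within the scatter). The estimate for compound 4 is 5000 nM, within 1800 nM to 14000 nM.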

Compound 4, half-maximal inhibitory concentration: 8300 nM
The estimate for compound 4 lay 1.7-fold (0.22 log units) below the measured number, and the stated range covers the measured number.
By their numbers in this assay, from the lowest: compound 1; then compounds 4, 2 and 3 (each within the scatter of the next, the first and the last beyond it).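

In this assay, the change from the 3-(methoxycarbonyl)propyl chain on the amide nitrogen to hydroxymethyl gives a step that can be read directly (a 3.3-fold higher number from compound 1 to compound 4 (0.52 log units; beyond the scatter)). Going by these compounds alone, the only earlier step in this region stayed within the scatter (a 1.6-fold higher number from compound 2 to compound 3 (0.20 log units; within the scatter)), so this is the first sign that changing the group on this amide nitrogen can shift the number by more than the scatter, although the shift is modest.

The pair leaves open whether the ester or the chain length matters, since both change together in this one step. A plain butyl chain, or a carboxylic acid or an amine at the end of the same chain, would help separate the two. No measurement shown here explains the step.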